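Removing One Methyl from Compound 1: What Clearance to Expect

The source may report more compounds than this note shows. Statements on the series, on what has been measured and on what is new or still open speak of the compounds shown alone.

Compound 1 `COc1ccc2nc(C)cc(OCC(=O)Nc3cc(C)cc(C)c3)c2c1`: 18.9 mL.min-1.g-1
Compound 2 `Cc1cc(C)cc(NC(=O)COc2cc(C)nc3ccc(C)cc23)c1`: 21.9 mL.min-1.g-1
Compound 3 `COc1ccc2nc(C)cc(OCCNc3cc(C)cc(C)c3)c2c1`: 86.5 mL.min-1.g-1

Of the compounds shown here, three sharing the core of compound 1 have been measured in an ADME assay on microsomes from liver (Mus musculus) for metabolic stability, read by LC-MS, using NADPH, with a stated time of 30 min, tested at 0.5 uM; on this read-out lower numbers stand for slow clearance and higher numbers for fast clearance. Compound 1 sits at the low end of the three readings, with 18.9 mL.min-1.g-1. Compound 2, which carries a methyl where compound 1 carries a methoxy on an aromatic carbon, is indistinguishable from it: the change a 1.2-fold higher number from compound 1 to compound 2 (0.06 log units; within the scatter). In compound 3 the amide is replaced by a two-carbon linker to the aniline nitrogen, and compound 3 gives 86.5 mL.min-1.g-1, a reading beyond the scatter of compound 1 and compound 2.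

Compound 4 `COc1ccc2nc(C)cc(OCC(=O)Nc3cccc(C)c3)c2c1` is not yet measured. It differs from compound 1 in one place: hydrogen in place of methyl on an aromatic carbon. Going by the values given here, no measured step bears directly on this change; the only single-point step available, from compound 1 to compound 2, concerned a different position and stayed within the scatter. With nothing else to go on, the trimming of one methyl is expected to leave the number of compound 4 close to that of compound 1, as a step of a 1.1-fold lower number from compound 1 to compound 4 (0.05 log units; within the scatter) that would not exceed the scatter. Compound 4 is therefore estimated at 17 mL.min-1.g-1, with a range from 9 mL.min-1.g-1 to 34 mL.min-1.g-1.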

Compound 4, intrinsic clearance in microsomes: 18.1 mL.min-1.g-1
Beside the measured number, compound 4's estimate is 1.1-fold (0.03 log units) below it; low and high end bracket the measured number.
By their numbers in this assay, from the lowest: compounds 4, 1 and 2 (each within the scatter of the next); then compound 3.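

Going from the 3,5-dimethylphenyl of compound 1 to the 3-methylphenyl of compound 4 gives a 1.0-fold lower number from compound 1 to compound 4 (0.02 log units; within the scatter) in this assay, the first measured step at this position. Within this pair, taking away one methyl from an aromatic carbon of this ring leaves no readable difference in clearance, as was also the case for the change at the other position, a 1.2-fold higher number from compound 1 to compound 2 (0.06 log units; within the scatter). The data offer no measurement that speaks to why the reading holds at this position.

The compounds shown do not tell whether the remaining methyl could also be replaced by hydrogen, or whether a different group at this place, such as a chlorine, an amine or a carboxylic acid, would leave the number where it is. They also leave open whether the same loss of a methyl would stay as small with the two-carbon linker of compound 3, which gives 86.5 mL.min-1.g-1.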